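Chloro to Trifluoromethyl on the Phenyl of Compound 2

The source may report more compounds than this note shows. Statements on the series, on what has been measured and on what is new or still open speak of the compounds shown alone.

Compound 1, `CCc1ccc(-n2nc(-c3ccc(C(F)(F)F)cc3O)nc2-c2ccccc2O)cc1`, gives 107% in a functional assay on PC-12 cells (Rattus norvegicus) for cytotoxicity, read by MTT assay, with stated times of 2 h and 24 h, tested at 10 uM; a lower number here means a weaker effect, a higher number a stronger effect of the compound at the concentration tested.
Compound 2, `Oc1cc(C(F)(F)F)ccc1-c1nc(-c2ccccc2O)n(-c2ccc(Cl)cc2)n1`, gives 96.1% in this assay.

For the measured compounds named here, of these two numbers compound 2 holds the lower one; the only measured step, a number 10.9 percentage points lower from compound 1 to compound 2 (beyond the scatter), separates it from compound 1. Compound 3, `Oc1cc(C(F)(F)F)ccc1-c1nc(-c2ccccc2O)n(-c2ccc(C(F)(F)F)cc2)n1`, is reached from compound 2 by a single exchange: trifluoromethyl in place of chloro on an aromatic carbon. Going by the values given here, no measured step compares chloro with trifluoromethyl at this place. Among the compounds with values here, the one known step, a number 10.9 percentage points lower from compound 1 to compound 2 (beyond the scatter), concerns ethyl against chloro, and it stayed modest. With nothing in the data pointing to a particular direction, the change from compound 2 to compound 3 is expected to be a number 2.9 percentage points higher from compound 2 to compound 3 (within the scatter), that is, no shift beyond the scatter. Compound 3 is therefore estimated at 99% in this assay, with a range from 85% to 113%.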

Compound 3, a percentage reported as activity, at one concentration (the size of the read-out at that concentration, not a potency): 102%
Beside the measured number, compound 3's estimate is 3 percentage points below it; low and high end bracket the measured number.
By their numbers in this assay, from the lowest: compounds 2, 3 and 1 (each within the scatter of the next, the first and the last beyond it).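

In this assay, trifluoromethyl on this aromatic carbon, para to a large group, gives a number 5.9 percentage points higher from compound 2 to compound 3 (within the scatter) when it replaces chloro, and a number 5 percentage points lower from compound 1 to compound 3 (within the scatter) when it replaces ethyl. The earlier step showed only that ethyl and chloro could be told apart here; compound 3 cannot be told apart from either compound 2 or compound 1, so this third group adds no separate step beyond the scatter. Nothing available explains these differences at this position.

From the compounds shown here alone, whether an amine, a carboxylic acid or a longer chain such as butyl on this carbon would stay as close to these compounds remains open. The compounds shown also leave open whether swapping the two hydroxy groups on the shared core for methoxy would change the read-out.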